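A few compounds are considered here, and "the series" means these few. Any claim that something is new, unique, unknown or untested is made for them only; others in the source may bear on it.

compound 1 `CCCCCCCC[C@@]1(C)SC(O)=C(C)C1=O`: 16.5 ug/mL
compound 2 `C=CCC1=C(O)S[C@](C)(CCCCCCCC)C1=O`: 34.8 ug/mL

In a functional assay on MCF7 cells (Homo sapiens) for inhibition (on this read-out higher numbers stand for weaker inhibition and lower numbers for stronger inhibition), compound 2 gives the higher of the two numbers, 34.8 ug/mL, which makes it the weaker inhibitor of the pair. The unmeasured compound 3 `CCCCCCCC[C@@]1(C)SC(O)=C(C(=O)OC)C1=O` differs from compound 2 in one place, with methoxycarbonyl in place of allyl on a double-bonded ring carbon. Within the data shown here, only one measured step bears on this place. It is a 2.1-fold higher number from compound 1 to compound 2 (0.32 log units; beyond the scatter), a modest change just beyond the scatter, seen when vinyl replaces hydrogen on a saturated chain carbon bound to that ring carbon. Among the measured compounds shown here, no measured compound carries methoxycarbonyl there, so the direction remains uncertain, and only a small change is expected. The expected step is a 1.2-fold lower number from compound 2 to compound 3 (0.06 log units; within the scatter), which may not exceed the scatter. Compound 3 is estimated at 30 ug/mL, with an expected range of 12 ug/mL to 75 ug/mL.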

Compound 3, half-maximal inhibitory concentration: 18.7 ug/mL
Estimate against measurement, compound 3: 1.6-fold (0.21 log units) above, within the range that was stated.
By their numbers in this assay, from the lowest: compounds 1, 3 and 2 (each within the scatter of the next, the first and the last beyond it).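

In this assay, methoxycarbonyl in place of allyl on this double-bonded ring carbon gives a 1.9-fold lower number from compound 2 to compound 3 (0.27 log units; within the scatter), and methoxycarbonyl in place of methyl gives a 1.1-fold higher number from compound 1 to compound 3 (0.05 log units; within the scatter). Both steps lie within the scatter, so this position accepts a group with two hydrogen-bond acceptors and no measurable separation from either neighbour, something the allyl and methyl pair alone could not show. Nothing measured here explains this result. The compounds shown leave open how an amine or a carboxylic acid on this ring carbon would read in this assay. They also leave open whether a longer ester chain in place of the methoxycarbonyl would give a step beyond the scatter.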